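Moving the methoxy group around the aryl ring of compound 1

This account rests on a few compounds, and the source may have more. Where it says the series, first, only, none or still open, it means among the compounds named here.

Measured compounds in this series:
- compound 1, `COc1ccc(-c2c(C)nn(-c3nc(-c4ccc(Cl)c(Cl)c4)c(SC(C)C)s3)c2C(=O)O)cc1`: 2100 nM
- compound 2, `Cc1nn(-c2nc(-c3ccc(Cl)c(Cl)c3)c(SC(C)C)s2)c(C(=O)O)c1-c1cncc(C#N)c1`: 20000 nM
- compound 3, `COc1cc(C#N)cc(-c2c(C)nn(-c3nc(-c4ccc(Cl)c(Cl)c4)c(SC(C)C)s3)c2C(=O)O)c1`: 5200 nM

All three were tested in a functional assay on BJAB cells (Homo sapiens) for antiproliferative activity, with a stated time of 4 days; on this read-out lower numbers stand for an effect already at smaller amounts and higher numbers for an effect only at larger amounts of compound. Compound 1 gives the lowest number of the three; its nearest neighbour is compound 3 with a 2.5-fold higher number from compound 1 to compound 3 (0.39 log units; beyond the scatter), and its most distant is compound 2 with a 9.5-fold higher number from compound 1 to compound 2 (0.98 log units; beyond the scatter). Between those two, a 3.8-fold lower number from compound 2 to compound 3 (0.59 log units; beyond the scatter).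

Compound 4, `COc1cccc(-c2c(C)nn(-c3nc(-c4ccc(Cl)c(Cl)c4)c(SC(C)C)s3)c2C(=O)O)c1`, has not yet been measured. It differs from compound 1 in a single place: 3-methoxyphenyl in place of 4-methoxyphenyl on an aromatic carbon. Among the compounds with values here, no measured pair reports exactly this change, so the expectation rests on compound 3, whose ring also carries a methoxy group in the 3-position together with a nitrile, and which shows a 2.5-fold higher number from compound 1 to compound 3 (0.39 log units; beyond the scatter). That step is modest, and the change to compound 4 is smaller still, since only the position of the methoxy group is altered and nothing is added. Compound 4 is therefore expected to give a number close to that of compound 1 or somewhat higher, so that the step is estimated at a 1.5-fold higher number from compound 1 to compound 4 (0.18 log units; within the scatter). On this basis compound 4 is estimated at 3200 nM, with a range from 1200 nM to 8500 nM.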

Compound 4, half-maximal effective concentration: 14000 nM
Compound 4: the middle estimate sits 4.4-fold (0.64 log units) below what was measured; the whole stated range lies below it.
By their numbers in this assay, from the lowest: compound 1; then compound 3; then compounds 4 and 2 (each within the scatter of the next).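

Moving the methoxy group alone counts for much at this position: in this assay, with the atoms unchanged, the swap of 4-methoxyphenyl for 3-methoxyphenyl gives a 6.7-fold higher number from compound 1 to compound 4 (0.82 log units; beyond the scatter), a larger step than the one seen earlier with the added nitrile. Taking the nitrile away while keeping the methoxy group gives a 2.7-fold higher number from compound 3 to compound 4 (0.43 log units; beyond the scatter), so the lower number of the 3-cyano-5-methoxyphenyl ring depends on the nitrile and is not carried by the methoxy group in that position alone. The remaining step, a 1.4-fold lower number from compound 2 to compound 4 (0.15 log units; within the scatter), lies within the scatter, so the 3-methoxyphenyl and 5-cyanopyridin-3-yl groups cannot be told apart on this read-out.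

Going by these compounds, it remains open whether a hydroxy or ethoxy group, or a plain phenyl ring, would fit into this order, and so whether the difference between the two methoxyphenyl rings is specific to methoxy. On these data alone, it is also open whether the same order of rings would hold with an amide in place of the carboxy group on the neighbouring ring atom. No measurement at hand accounts for the size of these steps.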